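Amide substituent step from compound 2 to compound 3

A few compounds are considered here, and "the series" means these few. Any claim that something is new, unique, unknown or untested is made for them only; others in the source may bear on it.

Measured so far in a functional assay on K562 cells (Homo sapiens) for antiproliferative activity, read by CCK-8 assay, with a stated time of 72 h; on this read-out higher numbers stand for weaker inhibition of growth and lower numbers for stronger inhibition of growth:
- compound 1 `CCC1C(=O)N(C)c2cnc(-n3ccc4cc(C(=O)NC)ccc43)nc2N1c1ccn(C)n1` gives 13300 nM
- compound 2 `CCNC(=O)c1ccc2c(ccn2-c2ncc3c(n2)N(c2ccn(C)n2)C(CC)C(=O)N3C)c1` gives 12800 nM

Compound 2 stands at 12800 nM, within the scatter of compound 1 at 13300 nM. Compound 3 `CCC1C(=O)N(C)c2cnc(-n3ccc4cc(C(=O)NC5CCCC5)ccc43)nc2N1c1ccn(C)n1` has not yet been measured. It differs from compound 2 as follows: cyclopentyl in place of ethyl on an amide-type nitrogen. In words, this is cyclopentyl in place of ethyl on an amide-type nitrogen. For the measured compounds named here, one measured step bears on it, a 1.0-fold lower number from compound 1 to compound 2 (0.02 log units; within the scatter), a change in the chain on that same amide-type nitrogen, and it stays within the scatter. On that evidence, no step beyond the scatter is expected in this assay. Going by the values given here, no measured compound carries a ring on this nitrogen, so the range is kept wide. Compound 3 is estimated at 11000 nM, with an expected range from 4000 nM to 30000 nM. The expected change is a 1.2-fold lower number from compound 2 to compound 3 (0.07 log units; within the scatter).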

Compound 3, concentration for 50% growth inhibition: 31300 nM
Estimate against measurement, compound 3: 2.8-fold (0.45 log units) below; the measured number lies above the stated range.
By their numbers in this assay, from the lowest: compounds 2 and 1 (each within the scatter of the next); then compound 3.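

At the amide-type nitrogen, this assay now gives a step beyond the scatter: cyclopentyl in place of ethyl gives a 2.4-fold higher number from compound 2 to compound 3 (0.39 log units; beyond the scatter) and cyclopentyl in place of methyl gives a 2.4-fold higher number from compound 1 to compound 3 (0.37 log units; beyond the scatter) on the same read-out. This nitrogen therefore does not tolerate every substituent equally, which the methyl and ethyl pair alone could not show, and compound 3 stands on the side of weaker inhibition of growth, though only modestly. Nothing measured here says what lies behind this step.

Still open, from the compounds shown here alone, is whether the ring itself or the larger number of carbons goes with the higher number, and a longer open chain such as pentyl on this nitrogen would separate the two. A smaller ring such as cyclopropyl, or a chain ending in an amine, would show how far the trend holds.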